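The source may hold more compounds than are shown below. What is called first, only, known or untested is meant among the compounds shown, and "the series" means these compounds.

Compound 1 `Cc1cc(N2CC[C@@H](C)[C@@H](N(C)c3ncnc4[nH]ccc34)C2)n2nc(SCC3CC3)nc2n1`: 9540 nM
Compound 2 `COc1ccc(CSc2nc3nc(C)cc(N4CC[C@@H](C)[C@@H](N(C)c5ncnc6[nH]ccc56)C4)n3n2)cc1`: 15200 nM

In a functional assay on MGC-803 cells (Homo sapiens) for inhibition, read by MTT assay, with a stated time of 72 h (a lower number here means a stronger inhibitor, a higher number a weaker inhibitor), compound 2 holds the higher of the two numbers, yet its gap to compound 1, a 1.6-fold higher number from compound 1 to compound 2 (0.20 log units; within the scatter), lies within the scatter, so the two cannot be told apart. Compound 3 `Cc1ccc(CSc2nc3nc(C)cc(N4CC[C@@H](C)[C@@H](N(C)c5ncnc6[nH]ccc56)C4)n3n2)cc1` differs from compound 2 by methyl in place of methoxy on an aromatic carbon. Among the measured compounds shown here, no measured step touches that position; the one step seen, already noted, stayed within the scatter, and a similarly small outcome is expected here, with no clear direction. Compound 3 is estimated at 14000 nM, between 6000 nM and 35000 nM. That corresponds to an expected step of a 1.1-fold lower number from compound 2 to compound 3 (0.04 log units; within the scatter), within the scatter.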

Compound 3, half-maximal inhibitory concentration: 5860 nM
For compound 3 the middle estimate is 2.4-fold (0.38 log units) above the measured one; measured number below the stated range.
By their numbers in this assay, from the lowest: compounds 3, 1 and 2 (each within the scatter of the next, the first and the last beyond it).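

In this assay, among the compounds shown here, the group on the six-membered aromatic ring matters: methyl in place of methoxy gives a 2.6-fold lower number from compound 2 to compound 3 (0.41 log units; beyond the scatter) and is the only step so far beyond the scatter. By contrast, 4-methylphenyl in place of cyclopropyl gives a 1.6-fold lower number from compound 1 to compound 3 (0.21 log units; within the scatter) and stays within the scatter, so these two groups cannot be told apart. Nothing shown here explains why methyl and methoxy differ. On these data alone, it remains open whether a chlorine, an amine or a longer chain at the same place would lower the number further. Whether the methyl result would hold at another ring position is also unknown.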